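The source may hold more compounds than are shown below. What is called first, only, known or untested is meant among the compounds shown, and "the series" means these compounds.

Measured compounds and their values:
compound 1, `Nc1ccccc1NC(=O)c1ccc(CSC(=S)N2CCCc3ccccc32)cc1`, gives 35.7% in a functional assay on HeLa cells (Homo sapiens) for antiproliferative activity, read by CCK-8 assay, with a stated time of 72 h, tested at 8 uM; on this read-out lower numbers stand for a weaker effect and higher numbers for a stronger effect at the one concentration tested
compound 2, `CC1CCCCN1C(=S)SCc1ccc(C(=O)Nc2ccccc2N)cc1`, gives 76.3%
compound 3, `CN(Cc1ccncc1)C(=S)SCc1ccc(C(=O)Nc2ccccc2N)cc1`, gives 72.7%

Compound 3 stands second highest of the three numbers. Its nearest neighbour is compound 2: the step of a number 3.6 percentage points lower from compound 2 to compound 3 (within the scatter) lies within the scatter. Its furthest is compound 1: the step of a number 37 percentage points higher from compound 1 to compound 3 (beyond the scatter) lies well beyond it.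

Compound 4, `Nc1ccccc1NC(=O)c1ccc(CSC(=S)N2CCCC2)cc1`, differs from compound 3 by a single exchange on the thiocarbonyl carbon: pyrrolidin-1-yl in place of methyl((pyridin-4-yl)methyl)amino on a thiocarbonyl carbon

All three measured steps concern this same position. The two large steps, a number 40.6 percentage points higher from compound 1 to compound 2 (beyond the scatter) and a number 37 percentage points higher from compound 1 to compound 3 (beyond the scatter), both arise when 1,2,3,4-tetrahydroquinolin-1-yl is replaced by a smaller amine; between 2-methylpiperidin-1-yl and methyl((pyridin-4-yl)methyl)amino, by contrast, a number 3.6 percentage points lower from compound 2 to compound 3 (within the scatter) is within the scatter. Pyrrolidin-1-yl resembles 2-methylpiperidin-1-yl in being a small non-aromatic ring, so no step beyond the scatter is expected for a number 1.7 percentage points lower from compound 3 to compound 4 (within the scatter).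

Compound 4 is therefore estimated at 71%, with a range from 52% to 88%.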

Compound 4, a percentage reported as inhibition, at one concentration (the size of the read-out at that concentration, not a potency): 77.8%
The estimate for compound 4 lay 6.8 percentage points below the measured number; measured number inside the range.
By their numbers in this assay, from the lowest: compound 1; then compounds 3, 2 and 4 (each within the scatter of the next).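

In this assay, pyrrolidin-1-yl on the thiocarbonyl carbon proves as well tolerated as the two other amines that carry no fused ring: a number 5.1 percentage points higher from compound 3 to compound 4 (within the scatter) and a number 1.5 percentage points higher from compound 2 to compound 4 (within the scatter), and both steps stay within the scatter. The first of these steps removes the six-membered aromatic ring and the hydrogen-bond acceptor of methyl((pyridin-4-yl)methyl)amino, so among these compounds neither feature is needed to hold the read-out at this level. With a number 42.1 percentage points higher from compound 1 to compound 4 (beyond the scatter) as a third large step, compound 1 now stands alone, beyond the scatter of compound 2, compound 3 and compound 4, which cannot be told apart.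

Nothing available here explains why 1,2,3,4-tetrahydroquinolin-1-yl stands apart. From the compounds shown here alone, it remains open whether an open-chain amine such as diethylamino, or a morpholin-4-yl ring, would stay level with this group.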